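Sulfonyl aryl trimming on a tertiary amide series

The source may report more compounds than this note shows. Statements on the series, on what has been measured and on what is new or still open speak of the compounds shown alone.

Compound 1 `COc1cccc(N2CCN(C(=O)C3CN(S(=O)(=O)c4ccc(OC)c5ccccc45)c4ccccc43)CC2)c1` — in a functional assay on CHO cells for antagonist activity at 5-hydroxytryptamine receptor 6 (Homo sapiens), read by FLIPR (on this read-out lower numbers stand for stronger inhibition and higher numbers for weaker inhibition), compound 1 gives 63.1 nM.
Compound 2 `CCN(CC)CCCNC(=O)C1CN(S(=O)(=O)c2ccc(OC)c3ccccc23)c2ccccc21` — in this assay compound 2 gives 79.4 nM.
Compound 3 `CN1CCC(N(C)C(=O)C2CN(S(=O)(=O)c3ccc4ccccc4c3)c3ccccc32)CC1` — in this assay compound 3 gives 25.1 nM.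

Compound 3 stands lowest of the three in this assay. Its gap to compound 1 and the wider gap to compound 2 both lie beyond the usual scatter, so compound 3 is the most potent of the measured set. Within the data shown here, no two of the three differ in a single place, so no step between measured compounds can be read off; the gaps above are the only comparisons the numbers allow.

Compound 4 `CN1CCC(N(C)C(=O)C2CN(S(=O)(=O)c3ccccc3)c3ccccc32)CC1` is not yet measured. It differs from compound 3 in one place: phenyl in place of naphthalen-2-yl on a sulfonyl sulfur. Among the measured compounds shown here, none of the measured compounds carries a phenyl on the sulfonyl sulfur, so nothing in the set shows directly what this change does. The working expectation is a weakening beyond the scatter, that is a higher number, of moderate size: the step from compound 3 to compound 4 is estimated at a 4.0-fold higher number from compound 3 to compound 4 (0.60 log units; beyond the scatter). Compound 4 is therefore expected to come in near 100 nM, with a range from 30 nM to 400 nM.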

Compound 4, inhibition constant: 316 nM
Estimate against measurement, compound 4: 3.2-fold (0.50 log units) below, and the stated range covers the measured number.
By their numbers in this assay, from the lowest: compound 3; then compounds 1 and 2 (each within the scatter of the next); then compound 4.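

In this assay, among these compounds, trimming the sulfonyl aryl from naphthalen-2-yl to phenyl gives a large step, a 13-fold higher number from compound 3 to compound 4 (1.10 log units; beyond the scatter), which is the first single-change effect measured and lies beyond the scatter. Neither group carries hydrogen-bond donors, hydrogen-bond acceptors or a net charge, so the change as counted is the loss of one of the two six-membered aromatic rings of carbon only, and the value of compound 3 at 25.1 nM is not kept with a single ring on the sulfonyl sulfur. Nothing at hand bears on the reason for the size of this step.

Open, from the compounds shown here alone, is whether a single ring can regain the lost ground once it carries a substituent, such as a chlorine atom or a methoxy group on the phenyl, or whether the second aromatic ring itself is needed. Also open, going by these compounds, is how the methoxy-bearing naphthalene sulfonyl of compounds 1 and 2 compares with naphthalen-2-yl on the amide of compound 3, since those compounds differ from it in more than one place.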